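A few compounds are considered here, and "the series" means these few. Any claim that something is new, unique, unknown or untested is made for them only; others in the source may bear on it.

Three compounds have been measured in an assay on microsomes from liver for inhibition of 3-hydroxy-3-methylglutaryl-coenzyme A reductase (Rattus norvegicus); on this read-out lower numbers stand for stronger inhibition and higher numbers for weaker inhibition:

Compound 1 `CC[C@H](C)C(=O)O[C@H]1C[C@@H](C)C=C2C=C[C@H](C)[C@H](CC[C@@H]3C[C@@H](O)CC(=O)O3)[C@]21C`: 3 nM
Compound 2 `COc1ccc(-c2nc(C(F)(F)F)n(CC[C@@H](O)C[C@@H](O)CC(=O)O)c2-c2ccc(F)cc2)cc1`: 68 nM
Compound 3 `Cc1cccc(-c2c(-c3ccc(F)cc3)nc(C(F)(F)F)n2CC[C@@H](O)C[C@@H](O)CC(=O)O)c1`: 74 nM

Compound 3 gives the highest of the three numbers in this assay. Its gap to compound 2 lies within the scatter of repeated measurements, so the two cannot be told apart on these data. Its gap to compound 1, whose number is far lower, lies beyond the scatter, and compound 1 is the only one of the three that clearly stands apart.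

Compound 4 `Cc1cc(C)cc(-c2c(-c3ccc(F)cc3)nc(C(F)(F)F)n2CC[C@@H](O)C[C@@H](O)CC(=O)O)c1` has not yet been measured. It differs from compound 3 in one place: methyl in place of hydrogen on an aromatic carbon. Cut one bond further out, the change reads 3-methylphenyl to 3,5-dimethylphenyl, on the ring that already carries one methyl group.

Going by the values given here, no step between two measured compounds covers this change, so nothing in the data sets its size. Compound 2 and compound 3 show that a different substituent on that same ring left the number within the scatter. A second methyl group on the ring is therefore expected to move the number little, with no step beyond the scatter: compound 4 is expected to give 85 nM (range 30 nM to 240 nM), which would mean a step of a 1.1-fold higher number from compound 3 to compound 4 (0.06 log units; within the scatter).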

Compound 4, half-maximal inhibitory concentration: 38 nM
Beside the measured number, compound 4's estimate is 2.2-fold (0.35 log units) above it, within the range that was stated.
By their numbers in this assay, from the lowest: compound 1; then compounds 4, 2 and 3 (each within the scatter of the next).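

In this assay the change from 3-methylphenyl to 3,5-dimethylphenyl now has a measured size, the step of a 1.9-fold lower number from compound 3 to compound 4 (0.29 log units; within the scatter) and so compound 3 and compound 4 cannot be told apart on these data. Going by these compounds alone, this is the first step in the set between two compounds that differ in one place, and it shows that a methyl group on this aromatic carbon, meta to a large group and meta to a methyl group, leaves the number within the scatter of the compound that carries hydrogen there. No measured information available here offers an explanation for this result.

The compounds shown leave open whether a group other than methyl on the same aromatic carbon, such as an ethyl group, a tert-butyl group, an amine or a carboxylic acid, would also stay within the scatter or would produce a step beyond it. They also leave open whether a methyl group in place of hydrogen would give a step of similar size on any other aromatic carbon of the shared core.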